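Working notes: aryl amine variation on the shared core

The source may hold more compounds than are shown below. What is called first, only, known or untested is meant among the compounds shown, and "the series" means these compounds.

Measured so far in a functional assay on A-431 cells (Homo sapiens) for antiproliferative activity, read by MTT assay, with a stated time of 72 h; a higher number here means a weaker inhibitor, a lower number a stronger inhibitor:
compound 1 `COc1cc2ncnc(Nc3ccc(F)c(Cl)c3)c2cc1OCCCCC(=O)Nc1ccc(S(N)(=O)=O)cc1`: 5020 nM
compound 2 `COc1cc2ncnc(Nc3cccc(Br)c3)c2cc1OCCCCC(=O)Nc1ccc(S(N)(=O)=O)cc1`: 9750 nM

Among the compounds with values here, compound 1 holds the lower of the two numbers in this assay, with compound 2 as its only neighbour; the gap, a 1.9-fold higher number from compound 1 to compound 2 (0.29 log units; within the scatter), stays within the scatter, so the two compounds cannot be placed in order. Compound 3 `COc1cc2ncnc(Nc3cccc(F)c3)c2cc1OCCCCC(=O)Nc1ccc(S(N)(=O)=O)cc1` is not yet measured. It differs from compound 1 by 3-fluorophenyl in place of 3-chloro-4-fluorophenyl on a nitrogen on an aromatic ring. Within the data shown here, the one measured step at the same place, from compound 1 to compound 2, is the only evidence that bears on this change, and it did not move the number beyond the scatter. On that basis no step beyond the scatter is expected in this assay from compound 1 to compound 3, with the wide range reflecting the thin evidence. Compound 3 is therefore estimated at 6500 nM, between 2500 nM and 17000 nM, which corresponds to an expected step of a 1.3-fold higher number from compound 1 to compound 3 (0.11 log units; within the scatter).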

Compound 3, half-maximal inhibitory concentration: 29900 nM
Beside the measured number, compound 3's estimate is 4.6-fold (0.66 log units) below it; the whole stated range lies below it.
By their numbers in this assay, from the lowest: compounds 1 and 2 (each within the scatter of the next); then compound 3.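

The aryl group on the nitrogen on an aromatic ring can move the number in this assay beyond the scatter, which the earlier pair did not show: 3-fluorophenyl in place of 3-chloro-4-fluorophenyl gives a 6.0-fold higher number from compound 1 to compound 3 (0.77 log units; beyond the scatter), and fluoro in place of bromo on an aromatic carbon gives a 3.1-fold higher number from compound 2 to compound 3 (0.49 log units; beyond the scatter). Among these three compounds, the two carrying chlorine or bromine on the phenyl ring hold the lower numbers, and none of the three goes against this. No data at hand account for these steps.

As far as these compounds go, whether 3-chlorophenyl would sit with compound 1 or with compound 3 remains open, so the separate roles of the chloro and the fluoro are unresolved. All three compounds share one chain and one sulfonamide, leaving open how a longer chain or a carboxylic acid in place of the sulfonamide would behave with these aryl groups.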